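A few compounds are considered here, and "the series" means these few. Any claim that something is new, unique, unknown or untested is made for them only; others in the source may bear on it.

Compound 1 `CC1=CCCC(C)(C)C1/C=C/C(=O)/C=C/c1ccccc1F` and compound 2 `CC1=CCCC(C)(C)C1/C=C/C(=O)/C=C/c1cc(C(F)(F)F)ccc1F` share one core and differ in a single place: trifluoromethyl in place of hydrogen on an aromatic carbon. In a functional assay on CWR22R cells (Homo sapiens) for cytotoxicity, read by MTT assay, with a stated time of 72 h (a higher number here means a weaker inhibitor, a lower number a stronger inhibitor), compound 1 gives 9400 nM, while compound 2 gives 3500 nM, so this change made a 2.7-fold lower number from compound 1 to compound 2 (0.43 log units; beyond the scatter). Compound 3 `CC1=C(/C=C/C(=O)/C=C/c2ccc(F)cc2)C(C)(C)CCC1O` is built on another core, and the difference between the two cores is not broken down here; in this assay compound 3 gives 7500 nM, which sits within the usual scatter of compound 1. Compound 4 `CC1=C(/C=C/C(=O)/C=C/c2ccc(F)c(C(F)(F)F)c2)C(C)(C)CCC1O` has not yet been measured. It differs from compound 3 by trifluoromethyl in place of hydrogen on an aromatic carbon. For the measured compounds named here, this is the same kind of change as the one seen between compound 1 and compound 2, but not the same: in compound 2 the new group stands meta to a large group and para to a fluoro group, whereas in compound 4 it stands ortho to a fluoro group and meta to a large group. The expectation rests on a 2.7-fold lower number from compound 1 to compound 2 (0.43 log units; beyond the scatter) and on compound 3 with 7500 nM. In this assay the expected step is a 2.3-fold lower number from compound 3 to compound 4 (0.37 log units; beyond the scatter), near the earlier one. Compound 4 is estimated at 3200 nM, most likely between 1500 nM and 7500 nM.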

Compound 4, half-maximal inhibitory concentration: 3200 nM
The estimate for compound 4 equals the measured number at the digits printed; low and high end bracket the measured number.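

Placing trifluoromethyl on an aromatic carbon of the core of compound 3 gave a 2.3-fold lower number from compound 3 to compound 4 (0.37 log units; beyond the scatter) in this assay, and this step agrees with the earlier one on the core of compound 1: the same change on two cores in this assay, a 2.7-fold lower number (0.43 log units; beyond the scatter) from compound 1 to compound 2 and a 2.3-fold lower number (0.37 log units; beyond the scatter) from compound 3 to compound 4, 1.1-fold (0.06 log units) apart, within the scatter of two such steps. In these four compounds, the change therefore carried over from one core to the other at about the same size, even though the new group in compound 4 stands ortho to a fluoro group and its place in compound 2 is not the same. Two pairs in this assay do not show that the step would hold on further cores or at other places on the ring, and they do not explain why the number falls.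

From the compounds shown here alone, it remains open whether another group at this place, such as a chlorine atom, a nitrile or a carboxylic acid, would shift the number in the same way. Also open is what each difference between the two cores contributes alone; no pair shown separates those differences.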